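A few compounds are considered here, and "the series" means these few. Any claim that something is new, unique, unknown or untested is made for them only; others in the source may bear on it.

In a functional assay on MCF7 cells (Homo sapiens) for cytotoxicity, read by MTT assay, with a stated time of 48 h (a lower number here means a stronger inhibitor, a higher number a weaker inhibitor), compound 1 `Fc1cccc(-c2nc(Nc3ccccc3)c3cc(F)ccc3n2)c1` gives 49700 nM. Compound 2 `Fc1ccc(Nc2nc(-c3cccc(F)c3)nc3ccc(F)cc23)cc1` reaches only the limit of > 50000 nM in this assay, not a number. Compound 3 `Fc1cccc(-c2nc(Nc3ccccc3Br)c3cc(F)ccc3n2)c1` likewise stops at the limit of > 50000 nM in this assay, so it stands at the weak end of what can be read. As far as these compounds go, the step from compound 1 to compound 2 is a number no lower from compound 1 to compound 2 (the limit leaves the size open), that from compound 1 to compound 3 is a number no lower from compound 1 to compound 3 (the limit leaves the size open), and a step that the two limits leave unreadable from compound 2 to compound 3 stays open. The whole picture is shaped by the limit of > 50000 nM in this assay, at which 2 of the 3 values shown sit.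

Compound 4 `Nc1cccc(Nc2nc(-c3cccc(F)c3)nc3ccc(F)cc23)c1` differs from compound 3 by 3-aminophenyl in place of 2-bromophenyl on a nitrogen on an aromatic ring. Among the compounds with values here, no measured step involves an amino group, so no change beyond the scatter is expected. Compound 4 is estimated at 50000 nM, between 20000 nM and 150000 nM. That estimate means an expected step of a number no higher from compound 3 to compound 4 (the limit leaves the size open).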

Compound 4, half-maximal inhibitory concentration: > 50000 nM
Compound 4: only a limit was reported; the forecaster's own chance of this, stated with the estimate: 60%; the middle value lies on the limit itself.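

In this assay, an amino group on the aniline ring leaves the compound at the same limit as the fluoro and bromo groups, so this third substituent also yields no readable number. Adding the amino group gives a number no lower from compound 1 to compound 4 (the limit leaves the size open), while the steps among the three compounds held at the limit cannot be read. One limit now shapes the series: the limit of > 50000 nM in this assay, at which 3 of the 4 values shown sit.

Compound 1 gives 49700 nM. As far as these compounds go, it remains open whether any group at this place can give a clearly lower value. A carboxylic acid on the ring, or a longer chain in place of the ring, could answer this.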